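A few compounds are considered here, and "the series" means these few. Any claim that something is new, unique, unknown or untested is made for them only; others in the source may bear on it.

Measured so far:
- compound 1 `CC(NC(=O)COc1cc(C(F)(F)F)c2c(-c3ccccc3)nn(C)c2n1)c1ccccn1`: 2670 nM
- compound 2 `Cc1nn(C)c(C)c1C(C)NC(=O)COc1cc(C(F)F)c2c(C3CC3)nn(C)c2n1`: 778 nM

Two compounds have numbers in a functional assay on isolated protein for antagonist activity at Orexin/Hypocretin receptor type 1 (Homo sapiens), read by fluorescence, FLIPR and calcium flux, with a stated time of 1 h; a lower number here means a stronger inhibitor, a higher number a weaker inhibitor. Compound 1 gives 2670 nM in this assay, and compound 2 gives 778 nM. Compound 2 therefore holds the lowest number of the two, and its gap to compound 1 is beyond the scatter. The two differ in several places at once, so the gap cannot be assigned to any single change.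

Compound 3 `Cc1nn(C)c(C)c1C(C)NC(=O)COc1cc(C(F)F)c2c(-c3ccccc3)nn(C)c2n1` is not yet measured. It differs from compound 2 in one place: phenyl in place of cyclopropyl on an aromatic carbon. The same phenyl is present in compound 1, but compound 1 also carries a different amide side chain and a trifluoromethyl group, so nothing recorded isolates the effect of the phenyl alone.

Without a matched step to lean on, the expectation for compound 3 is a shift that is at most modest, and more likely toward a higher number than toward a lower one, given that compound 1 with its phenyl gives 2670 nM. The estimated step from compound 2 to compound 3 is a 1.4-fold higher number from compound 2 to compound 3 (0.15 log units; within the scatter). For compound 3 the expected value in this assay is 1100 nM, with a range from 300 nM to 4000 nM.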

Compound 3, inhibition constant in the Orexin/Hypocretin receptor type 1 assay: 63 nM
For compound 3 the middle estimate is 17-fold (1.24 log units) above the measured one; the whole stated range lies above it.
By their numbers in the Orexin/Hypocretin receptor type 1 assay, from the lowest: compound 3; then compound 2; then compound 1.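

Among these compounds, in the Orexin/Hypocretin receptor type 1 assay, phenyl in place of cyclopropyl on an aromatic carbon gives a 12-fold lower number from compound 2 to compound 3 (1.09 log units; beyond the scatter), the first step with only one place changed. This position on the five-membered aromatic ring is therefore far from indifferent to its substituent, and the step arrives with no hydrogen-bond donor, hydrogen-bond acceptor or net charge entering or leaving, only a six-membered aromatic ring of carbon taking the place of a three-membered non-aromatic one. The same change also moves a physicochemical assay for lipophilicity, measured as octanol-water partition (a lower number here means a more polar compound, a higher number a more lipophilic compound), where compound 2 gives 2.8 and compound 3 gives 3.9. The gain in inhibition thus comes with a measured rise in lipophilicity: the measured partition coefficient of compound 2, 2.8, and of compound 3, 3.9, a number 1.10 log units higher (beyond the scatter)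

This single pair cannot separate the contribution of the aromatic ring from that of the higher lipophilicity, and whether the step carries over to the amide side chain of compound 1 also stays unresolved, since compound 1 differs from the others in more than one place. A pyridine ring at this place, with a ring nitrogen in the aromatic ring, or a phenyl bearing a methoxy group, would test whether the gain survives a change in the ring itself.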